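Flipping One Ring Stereocentre on a Near-Inactive Scaffold

The compounds below may be only part of what the source reports. "The series", "measured", "known", "first", "only" and "open" are said of these compounds alone.

The measured compounds and their readings:
compound 1 `CC(=O)OC[C@H]1O[C@@H](Oc2nc(-c3cccs3)cc(-c3ccc(Cl)cc3)c2C#N)[C@H](OC(C)=O)[C@@H]1OC(C)=O` — 2%
compound 2 `CC(=O)OC[C@H]1O[C@@H](Oc2nc(-c3cccs3)cc(-c3ccc(Cl)cc3)c2C#N)[C@H](OC(C)=O)[C@@H](OC(C)=O)[C@H]1OC(C)=O` — 0%
compound 3 `N#Cc1c(-c2ccc(Cl)cc2)cc(-c2cccs2)nc1O[C@@H]1O[C@H](CO)[C@@H](O)[C@H]1O` — 0%

All three were tested in a functional assay on MCF7 cells (Homo sapiens) for inhibition, read by MTT assay, with a stated time of 48 h, tested at 25 ug/mL; on this read-out lower numbers stand for a weaker effect and higher numbers for a stronger effect at the one concentration tested. There compound 1 gives 2%. Compound 2 gives 0%. Compound 3 gives 0%. Compound 1 carries the highest of the three numbers, yet its distance to compound 2 and to compound 3 is within the usual scatter of such measurements, so none of the three can be said to act more or less strongly than another; all sit at the bottom of the scale.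

Compound 4 `CC(=O)OC[C@H]1O[C@@H](Oc2nc(-c3cccs3)cc(-c3ccc(Cl)cc3)c2C#N)[C@H](OC(C)=O)[C@H]1OC(C)=O` is the unmeasured partner of compound 1. How it differs: the two compounds have the same atoms and bonds and differ only in configuration as drawn: 1 of 4 stereo elements differ; a stereocentre at a saturated ring carbon is drawn R in compound 1 and S in compound 4. Among the measured compounds shown here, no measured pair here shows what such a change in configuration alone does, so the only guide is the flat picture formed by compound 1, compound 2 and compound 3.

The step from compound 1 to compound 4 in this assay is expected to be no change at the digits printed from compound 1 to compound 4 (within the scatter), nothing beyond the scatter in either direction. Compound 4 is therefore estimated to give 2%, with a range from 0% to 10%.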

Compound 4, a percentage reported as inhibition, at one concentration (the size of the read-out at that concentration, not a potency): 0%
Compound 4: middle estimate off by 2 percentage points, on the high side, and the stated range covers the measured number.
By their numbers in this assay, from the lowest: compounds 2, 3, 4 and 1 (each within the scatter of the next).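

In this assay, among the compounds shown here, turning this saturated ring carbon from R to S gives a number 2 percentage points lower from compound 1 to compound 4 (within the scatter), the first reading of what a change in configuration alone does in this set. The comparison is a clean one, with a single point of difference: the fact that compounds 1 and 4 differ only in the configuration as drawn. At this ring carbon and on this scaffold, the change leaves no effect that can be told apart from the scatter, so the configuration drawn here makes no visible difference to the reading.

All four compounds sit at the bottom of the scale, which leaves open whether this stereocentre would matter in a compound with a clear effect. Also open, from the compounds shown here alone, is whether an amine or a carboxylic acid on the saturated ring, in place of the acetate esters, would lift the reading at all.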